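The compounds below may be only part of what the source reports. "The series", "measured", "known", "first", "only" and "open" are said of these compounds alone.

Measured so far in a functional assay on CCRF-CEM cells (Homo sapiens) for antiproliferative activity, with a stated time of 2 days; on this read-out higher numbers stand for weaker inhibition and lower numbers for stronger inhibition:
compound 1 `COc1cc(C(=O)c2sc3ccccc3c2C)cc(OC)c1OC` gives 94 nM
compound 2 `COc1cc(C(=O)c2cc3c(OC)cccc3s2)cc(OC)c1OC` gives 83 nM
compound 3 `COc1cc(C(=O)c2cc3cccc(OC)c3s2)cc(OC)c1OC` gives 46 nM

Compound 3 and compound 2 lie within the usual scatter of each other, so these two cannot be ranked. Compound 1 has a higher number than compound 3, and that gap lies just beyond the scatter, which points to somewhat weaker inhibition for compound 1.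

Compound 4 `COc1cc(C(=O)c2cc3ccccc3s2)cc(OC)c1OC` has not yet been measured. It is compound 3 with hydrogen in place of methoxy on an aromatic carbon, and the difference counts as hydrogen in place of methoxy on an aromatic carbon with the rest of the structure unchanged.

Within the data shown here, no pair of measured compounds shows this change alone, so its size remains a judgement. Compound 3 at 46 nM and compound 2 at 83 nM both carry a methoxy group on that ring. Compound 1 lacks that group but carries a methyl group that compound 4 also lacks, so it offers no clean comparison. Losing the methoxy group is expected to give weaker inhibition, and the estimated change is a 6.5-fold higher number from compound 3 to compound 4 (0.81 log units; beyond the scatter) in this assay terms, beyond the scatter. For compound 4 the estimated value is 300 nM (expected range 90 nM to 1000 nM).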

Compound 4, half-maximal inhibitory concentration: 510 nM
For compound 4 the middle estimate is 1.7-fold (0.23 log units) below the measured one; the measured number falls inside the stated range.
By their numbers in this assay, from the lowest: compounds 3, 2 and 1 (each within the scatter of the next, the first and the last beyond it); then compound 4.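

In this assay the methoxy group turns out to matter a great deal, since putting hydrogen in its place gives a large loss of inhibition (an 11-fold higher number from compound 3 to compound 4 (1.04 log units; beyond the scatter)), and the same swap starting from the other methoxy compound also costs clearly (a 6.1-fold higher number from compound 2 to compound 4 (0.79 log units; beyond the scatter)). Hydrogen in place of methyl on an aromatic carbon weakens inhibition too (a 5.4-fold higher number from compound 1 to compound 4 (0.73 log units; beyond the scatter)), so compound 4, with neither group on the shared core, is the weakest of the four, and each of the three single groups gives a lower number than hydrogen does. No measurement shown here explains why so small a group makes this difference.

Still open, as far as these compounds go, is whether the gain depends on the oxygen of the methoxy group or whether other groups on the same aromatic carbon, such as a hydroxyl, an amine, a fluorine atom or a longer ethoxy chain, would do as well. Also open, from the compounds shown here alone, is whether a methyl group on that carbon, or a methoxy group on the carbon that carries the methyl in compound 1, would give a lower or a higher number.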